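The source may report more compounds than this note shows. Statements on the series, on what has been measured and on what is new or still open speak of the compounds shown alone.

Measured so far in a functional assay on MGC-803 cells (Homo sapiens) for antiproliferative activity, read by MTT assay, with a stated time of 48 h; a higher number here means that more compound is needed for the effect, a lower number that less compound is needed:
- compound 1 `CC1=NN(S(=O)(=O)c2ccccc2C)C(c2cc(Br)ccc2O)C1`: > 60000 nM, a limit of the assay
- compound 2 `CC1=NN(S(=O)(=O)c2ccc(F)cc2)C(c2cc(Br)ccc2O)C1`: 15500 nM

For the measured compounds named here, compound 2 holds the only actual number, and the other entry is a limit, so there is no real range in which to rank it. The next compound, compound 3 `CC1=NN(S(=O)(=O)c2ccc(Cl)cc2Cl)C(c2cc(Br)ccc2O)C1`, keeps the shared core and has 2,4-dichlorophenyl in place of 4-fluorophenyl on a sulfonyl sulfur.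

Going by the values given here, one measured step bears on this, at the same place: an at least 3.8-fold lower number from compound 1 to compound 2 (0.58 log units; beyond the scatter). It lies beyond the scatter and shows that a change of group on the sulfonyl sulfur can shift the number in this assay. That step swapped 2-methylphenyl for 4-fluorophenyl and did not involve 2,4-dichlorophenyl, so it gives neither a firm size nor a firm direction here. No step beyond the scatter is therefore expected, though the uncertainty is wide: a 1.2-fold higher number from compound 2 to compound 3 (0.06 log units; within the scatter) is the estimated step. For compound 3 the estimate is 18000 nM, with an expected range of 6000 nM to 55000 nM.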

Compound 3, half-maximal effective concentration: 37900 nM
Estimate against measurement, compound 3: 2.1-fold (0.32 log units) below; the measured number falls inside the stated range.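

In this assay, the group on the sulfonyl sulfur now has a step with a measured number at both ends: a 2.4-fold higher number from compound 2 to compound 3 (0.39 log units; beyond the scatter). Among the three groups shown at this place, 4-fluorophenyl therefore gives the lowest number, and a second halogen on the phenyl ring does not bring any gain over compound 2 in this small set. The other new step, an at least 1.5-fold lower number from compound 1 to compound 3 (0.19 log units; that floor lies within the scatter), does not firmly separate 2,4-dichlorophenyl from 2-methylphenyl, as it rests on a limit for compound 1: the limit of > 60000 nM in this assay, at which 1 of the 3 values shown sits.

The change from compound 2 to compound 3 removes one fluorine and adds two chlorines at once, so the step cannot be assigned to the kind of halogen or to their number, and a phenyl ring carrying a single chlorine would help to separate the two. From the compounds shown here alone, it also remains open whether a group carrying an amine or a carboxylic acid on the sulfonyl sulfur would fall below the number of compound 2, and how the bromine and hydroxyl on the other aryl ring of the shared core contribute.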